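The source may hold more compounds than are shown below. What is called first, only, known or untested is meant among the compounds shown, and "the series" means these compounds.

Measured compounds in this study:

- Compound 1, `COc1cc(N)c(Cl)cc1NC(=O)C1CCN(CC2CC2)CC1`, reported only as a limit of the assay: > 10 mg/kg.
- Compound 2, `COc1cc(N)c(Cl)cc1NC(=O)C1CCN(CC2CCCCC2)CC1`: 2.9 mg/kg.
- Compound 3, `COc1cc(N)c(Cl)cc1NC(=O)C1CCN(Cc2ccccc2)CC1`: 0.5 mg/kg.

All three share one core and differ only in the group on a saturated chain carbon bound to an amine nitrogen in a ring. They were tested in a functional assay on the whole organism for antagonist activity, with Mus musculus as the target; on this read-out higher numbers stand for an effect only at larger amounts of compound and lower numbers for an effect already at smaller amounts. Among the two real numbers, compound 2 stands highest; its nearest neighbour is compound 3, reached by a 5.8-fold lower number from compound 2 to compound 3 (0.76 log units; beyond the scatter). Compound 1 gives no number at all, only the assay limit (the limit of > 10 mg/kg in this assay, at which 1 of the 3 values shown sits), so for it only a direction is known: an at least 3.4-fold lower number from compound 1 to compound 2 (0.53 log units; beyond the scatter) and an at least 20-fold lower number from compound 1 to compound 3 (1.30 log units; beyond the scatter).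

The next compound, compound 4, `COc1cc(N)c(Cl)cc1NC(=O)C1CCN(Cc2cccc(C)c2)CC1`, differs from compound 2 in one place: 3-methylphenyl in place of cyclohexyl on a saturated chain carbon bound to an amine nitrogen in a ring. The measured step that bears most directly on this is the exchange of cyclohexyl for phenyl, a 5.8-fold lower number from compound 2 to compound 3 (0.76 log units; beyond the scatter), a modest drop in the number. Compound 4 carries 3-methylphenyl, which is phenyl with one added methyl, so a step of similar direction and size is expected, the number falling. The expected step is a 4.8-fold lower number from compound 2 to compound 4 (0.68 log units; beyond the scatter). Compound 4 is therefore estimated at 0.6 mg/kg, with a likely range from 0.2 mg/kg to 2 mg/kg.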

Compound 4, dose for half-maximal effect: 2.4 mg/kg
The estimate for compound 4 lay 4.0-fold (0.60 log units) below the measured number; the whole stated range lies below it.
By their numbers in this assay, from the lowest: compound 3; then compounds 4 and 2 (each within the scatter of the next). At a limit, above all of these: compound 1.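

In this assay, this position proves sensitive to a very small change on the phenyl ring, since methyl in place of hydrogen on an aromatic carbon gives a 4.8-fold higher number from compound 3 to compound 4 (0.68 log units; beyond the scatter), a modest step. An aromatic ring alone is therefore not enough to set a compound apart from the cyclohexyl one: with 3-methylphenyl in place of cyclohexyl there is a 1.2-fold lower number from compound 2 to compound 4 (0.08 log units; within the scatter), so these two groups cannot be told apart here, and compound 4 goes against any simple rule that aromatic groups outdo saturated ones at this position. Compound 1 is known only as a limit of the assay, so an at least 4.1-fold lower number from compound 1 to compound 4 (0.61 log units; beyond the scatter) gives a direction and not a true size: the limit of > 10 mg/kg in this assay, at which 1 of the 4 values shown sits.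

On these data alone, whether this shift belongs to methyl in particular or would follow from other groups on the phenyl ring, such as fluorine, methoxy or hydroxyl, remains open. Also open, as far as these compounds go, is how a longer chain carrying the phenyl ring, or a pyridine ring in place of phenyl, would behave in this assay.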